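The compounds below may be only part of what the source reports. "The series", "measured", "known", "first", "only" and "open" are said of these compounds alone.

Of the compounds shown here, three sharing one core have been measured in an ADME assay on NHDF cells (Homo sapiens) for cytotoxicity, read by MTT assay, with a stated time of 72 h; on this read-out lower numbers stand for stronger inhibition and higher numbers for weaker inhibition. Compound 1 (`COc1ccccc1/C=C1\CCC/C(=C\c2cccc(OC)c2OC)C1=O`) gives 31300 nM, compound 2 (`COc1cc(/C=C2\CCC/C(=C\c3cccc(OC)c3OC)C2=O)cc(OC)c1`) gives 13100 nM, and compound 3 (`COc1ccc(/C=C2\CCC/C(=C\c3cccc(Cl)c3)C2=O)cc1OC`) gives 11900 nM. Compound 3 thus lies within the scatter of compound 2, while compound 1 carries a higher number than compound 3, a gap beyond the scatter.

The next compound, compound 4 (`COc1ccc(/C=C2\CCC/C(=C\c3cccc(Br)c3)C2=O)cc1OC`), differs from compound 3 in one place: bromo in place of chloro on an aromatic carbon, meta to a large group (bromo in place of chloro on an aromatic carbon). Within the data shown here, no measured pair in this set differs in only one place, so the data give no direct precedent for this swap. The expectation therefore starts from compound 3 at 11900 nM, and no change beyond the scatter is expected in this assay, in either direction. The estimated step of a 1.1-fold lower number from compound 3 to compound 4 (0.03 log units; within the scatter) is accordingly small. Compound 4 is expected at 11000 nM, with an estimated range of 6000 nM to 20000 nM.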

Compound 4, half-maximal inhibitory concentration: 12400 nM
Compound 4: middle estimate off by 1.1-fold (0.05 log units), on the low side, and the stated range covers the measured number.
By their numbers in this assay, from the lowest: compounds 3, 4 and 2 (each within the scatter of the next); then compound 1.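

In this assay, among these compounds, this pair gives the first reading of a change in one place, and going from 3-chlorophenyl to 3-bromophenyl amounts to a 1.0-fold higher number from compound 3 to compound 4 (0.02 log units; within the scatter) in this set. At this position, on an aromatic carbon meta to a large group, bromo can therefore stand in for chloro with no difference that this read-out can separate from repeat scatter. No supporting measurement is available to explain this result or bear on it.

On these data alone, what remains open is how this position responds to groups other than these two halogens, such as fluoro, an amine or a carboxylic acid. As far as these compounds go, it is also open whether the same swap reads alike elsewhere on the shared core, since this single pair speaks for one place only.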